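The source may report more compounds than this note shows. Statements on the series, on what has been measured and on what is new or still open speak of the compounds shown alone.

Measured so far, in a functional assay on MCF7 cells (Homo sapiens) for cytotoxicity, read by MTT assay; on this read-out lower numbers stand for stronger inhibition and higher numbers for weaker inhibition:
Compound 1, `CC(C)[C@H](NC(=S)Nc1cc(C(F)(F)F)cc(C(F)(F)F)c1)c1nc2ccccc2[nH]1`, gives 24300 nM.
Compound 2, `C[C@H](NC(=S)Nc1cc(C(F)(F)F)cc(C(F)(F)F)c1)c1nc2ccccc2[nH]1`, gives 187000 nM.
Compound 3, `CC(C)[C@@H](NC(=S)NCc1ccccc1)c1nc2ccccc2[nH]1`, gives 11100 nM.

Compound 1 and compound 2 differ in one place: methyl in place of isopropyl on a saturated chain carbon bound to an amide-type nitrogen and an aromatic carbon. That change made a 7.7-fold higher number from compound 1 to compound 2 (0.89 log units; beyond the scatter). Compound 3 has the lowest number of the three in this assay; how its core differs from the core of compound 1 is not broken down here.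

Compound 4, `C[C@@H](NC(=S)NCc1ccccc1)c1nc2ccccc2[nH]1`, has not yet been measured in this assay. It differs from compound 3 by methyl in place of isopropyl on a saturated chain carbon bound to an amide-type nitrogen and an aromatic carbon, the same change at the same place as the step from compound 1 to compound 2. Going by the values given here, the expected step is a 7.2-fold higher number from compound 3 to compound 4 (0.86 log units; beyond the scatter), because the one measured instance of this change gave a 7.7-fold higher number from compound 1 to compound 2 (0.89 log units; beyond the scatter) and nothing in the data suggests the different core would alter that. Compound 4 is therefore expected to give 80000 nM in this assay, with a likely range from 30000 nM to 220000 nM.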

Compound 4, half-maximal inhibitory concentration: 14300 nM
Beside the measured number, compound 4's estimate is 5.6-fold (0.75 log units) above it; measured number outside the range, below it.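

In this assay, methyl in place of isopropyl gives a 1.3-fold higher number from compound 3 to compound 4 (0.11 log units; within the scatter), so compound 3 and compound 4 cannot be told apart on this read-out, although the same change gave a clear step on the core of compound 1. The size of this step therefore did not carry from one core to the other, and the two instances disagree: the same change on two cores in this assay, a 7.7-fold higher number (0.89 log units; beyond the scatter) from compound 1 to compound 2 and a 1.3-fold higher number (0.11 log units; within the scatter) from compound 3 to compound 4, 6.0-fold (0.78 log units) apart, beyond the scatter of two such steps. This does not show which difference between the two cores is responsible, and two instances set no rule for the rest of the series.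

The compounds shown leave open how an ethyl group, a longer chain or an amine would behave on the saturated chain carbon bound to an amide-type nitrogen and an aromatic carbon. They also leave open whether the same change on a further core would resemble the step from compound 1 to compound 2 or the much smaller one from compound 3 to compound 4.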